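The compounds below may be only part of what the source reports. "The series", "measured", "known", "first", "only" and "open" are said of these compounds alone.

Measured so far:
Compound 1, `COc1ccc(OC)c(CN(C(=O)Nc2ccc(C)cc2)n2cnnc2)c1`, gives 17400 nM in a functional assay on A549 cells (Homo sapiens) for cytotoxicity, read by MTT assay, with a stated time of 48 h; a lower number here means a stronger inhibitor, a higher number a weaker inhibitor.
Compound 2, `COc1ccc(CN(C(=O)Nc2ccc(C)cc2)n2cnnc2)cc1OC`, gives 22200 nM in this assay.
Compound 3, `CCCCCCCCCNC(=O)N(Cc1cc(OC)ccc1OC)n1cnnc1`, gives only > 50000 nM in this assay, which is a limit of the assay and not a number.

Going by these compounds, compound 3 thus stands at the limit of > 50000 nM in this assay, at which 1 of the 3 values shown sits, so its exact potency is unknown, and the step from compound 1 was recorded only as an at least 2.8-fold higher number from compound 1 to compound 3 (0.45 log units; beyond the scatter). Compound 4, `COc1ccc(OC)c(CN(C(=O)NC2CCCCC2)n2cnnc2)c1`, differs from compound 3 by cyclohexyl in place of nonyl on an amide-type nitrogen. Among the measured compounds shown here, no measured step covers this exchange directly. The nearest one, an at least 2.8-fold higher number from compound 1 to compound 3 (0.45 log units; beyond the scatter), shows that trading a 4-methylphenyl ring for a nonyl chain weakened the compound, and compound 4 brings back a six-membered ring, though a non-aromatic one rather than an aromatic one. Compound 4 is therefore expected to come out somewhat stronger than the chain-bearing compound 3, while a reading at the limit again cannot be ruled out. This is expected to mean an at least 1.6-fold lower number from compound 3 to compound 4 (0.22 log units; that floor lies within the scatter) in this assay. The estimate for compound 4 is 30000 nM, with a range from 12000 nM to 60000 nM.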

Compound 4, half-maximal inhibitory concentration: 21500 nM
The estimate for compound 4 lay 1.4-fold (0.14 log units) above the measured number; the measured number falls inside the stated range.
By their numbers in this assay, from the lowest: compounds 1, 4 and 2 (each within the scatter of the next). At a limit, above all of these: compound 3.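

On the amide-type nitrogen, cyclohexyl in place of nonyl gives an at least 2.3-fold lower number from compound 3 to compound 4 (0.36 log units; beyond the scatter) in this assay, so a six-membered ring of carbon only reads better here than the long chain. The ring need not be aromatic: cyclohexyl in place of 4-methylphenyl gives a 1.2-fold higher number from compound 1 to compound 4 (0.09 log units; within the scatter), which leaves these two rings indistinguishable in this read-out. The first of these steps is only a floor, since compound 3 sits at a limit of the assay and not at a number: the limit of > 50000 nM in this assay, at which 1 of the 4 values shown sits.

Nonyl and cyclohexyl differ both in the ring and in the carbon count, so the compounds shown do not separate these two changes. Also open, going by these compounds, is how a short butyl chain, or a cyclohexyl ring carrying an amine or a carboxylic acid, would read at this position.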